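Compound 4: Trifluoromethylphenyl Replaces Cyanophenyl

The source may report more compounds than this note shows. Statements on the series, on what has been measured and on what is new or still open speak of the compounds shown alone.

In a functional assay on HCT-116 cells (Homo sapiens) for antiproliferative activity, read by MTT assay, with a stated time of 24 h (a lower number here means a stronger inhibitor, a higher number a weaker inhibitor), compound 3 `COc1cc(OC)c(-c2coc3cc(OCc4ccccc4C#N)ccc3c2=O)cc1OC` reaches the limit of > 10000 nM, which is a limit and not a number. Compound 1 `C#CCOc1ccc2c(=O)c(-c3cc(OC)c(OC)cc3OC)coc2c1` gives 8050 nM and compound 2 `COc1ccc2c(=O)c(-c3cc(OC)c(OC)cc3OC)coc2c1` gives 9170 nM, so the steps of an at least 1.2-fold higher number from compound 1 to compound 3 (0.09 log units; that floor lies within the scatter) and an at least 1.0-fold higher number from compound 2 to compound 3 (0.03 log units; that floor lies within the scatter) both stay within the scatter; each alters the same saturated chain carbon bound to an oxygen on an aromatic ring that is altered again here. Compound 4 `COc1cc(OC)c(-c2coc3cc(OCc4ccc(C(F)(F)F)cc4)ccc3c2=O)cc1OC` differs by 4-(trifluoromethyl)phenyl in place of 2-cyanophenyl on a saturated chain carbon bound to an oxygen on an aromatic ring. Since earlier changes at this place moved nothing beyond the scatter, compound 4 is expected to show the step that the limit leaves unreadable from compound 3 to compound 4 and is expected to end up again at a limit rather than a number. Compound 4 is estimated at 12000 nM, in a range from 5000 nM to 30000 nM.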

Compound 4, half-maximal inhibitory concentration: 2440 nM
Beside the measured number, compound 4's estimate is 4.9-fold (0.69 log units) above it; the measured number lies below the stated range.
By their numbers in this assay, from the lowest: compound 4; then compounds 1 and 2 (each within the scatter of the next). At a limit, above all of these: compound 3.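

At the saturated chain carbon bound to an oxygen on an aromatic ring, a change now moves the number beyond the scatter in this assay: an at least 4.0-fold lower number from compound 3 to compound 4 (0.61 log units; beyond the scatter), a 3.8-fold lower number from compound 2 to compound 4 (0.57 log units; beyond the scatter) and a 3.3-fold lower number from compound 1 to compound 4 (0.52 log units; beyond the scatter). So 2-cyanobenzyl and 4-(trifluoromethyl)benzyl are not interchangeable here: a benzyl group alone does not set the result. The first step is only a floor because compound 3 stands at a limit, not a number: the limit of > 10000 nM in this assay, at which 1 of the 4 values shown sits.

Compound 3 and compound 4 differ in both the ring's group and its place, and these two changes remain unseparated. As far as these compounds go, how an amine or a carboxylic acid on that ring would behave remains open.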